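Piperidinylmethyl added to the pyridine of compound 1

The source may report more compounds than this note shows. Statements on the series, on what has been measured and on what is new or still open speak of the compounds shown alone.

Working notes on a small set: two compounds measured, one awaiting measurement. Compound 1 `COC(=O)c1c(F)cccc1-c1ccc(CNc2ccccn2)c(F)c1` in an assay on isolated protein for binding affinity to B1 bradykinin receptor (Homo sapiens) (a higher number here means a weaker inhibitor, a lower number a stronger inhibitor), gives 815 nM. Compound 2 `COC(=O)c1c(Cl)cccc1-c1ccc(CNc2cc(CN3CCCCC3)ccn2)c(F)c1` in this assay gives 611 nM; the two numbers lie within the scatter of one another, so compound 1 stands at one end of a pair whose members cannot be told apart. Compound 2 differs from compound 1 in more than one place, so no single step can be read between them.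

Compound 3 `COC(=O)c1c(F)cccc1-c1ccc(CNc2ccc(CN3CCCCC3)cn2)c(F)c1` is the next compound to be measured. Its difference from compound 1 is (piperidin-1-yl)methyl in place of hydrogen on an aromatic carbon. For the measured compounds named here, no measured pair isolates this change. Compound 2 carries a group of the same name together with a second change and gives 611 nM, which shows no gain beyond the scatter against compound 1. For compound 3 the expected step of a 1.6-fold lower number from compound 1 to compound 3 (0.21 log units; within the scatter) is therefore small, a modest lowering of the number at most. Compound 3 is estimated at 500 nM, with a range from 150 nM to 1600 nM.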

Compound 3, inhibition constant: 9.1 nM
Compound 3: the middle estimate sits 55-fold (1.74 log units) above what was measured; the measured number lies below the stated range.
By their numbers in this assay, from the lowest: compound 3; then compounds 2 and 1 (each within the scatter of the next).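

In this assay, for the compounds shown here, the single change of (piperidin-1-yl)methyl in place of hydrogen gives a 90-fold lower number from compound 1 to compound 3 (1.95 log units; beyond the scatter) on the shared core, so this aromatic carbon, two atoms from the ring nitrogen and para to a large group, is a place where the added group goes with a large lowering of the number. Going by these compounds alone, this is the first reading of the group on its own, since compound 2 carries a group of the same name but differs from both compound 1 and compound 3 in more than one place, and no step involving compound 2 can be read. No measurement shown here accounts for the size of the step.

On these data alone, whether a step of this size remains with a morpholine ring, a dimethylamine or a primary amine in place of the piperidine, or with a longer chain linking the nitrogen to the aromatic ring, stays open. Within the data shown here, also open is whether the same group gives such a step on other aromatic carbons of this ring, as no pair here isolates a change of place alone.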